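Swapping a Sulfonamide for an Amide on the Aryl Ring

A few compounds are considered here, and "the series" means these few. Any claim that something is new, unique, unknown or untested is made for them only; others in the source may bear on it.

Compound 1: `CS(=O)(=O)Nc1ccc(-c2cc(C(=O)N[C@H]3CCCNC3)c(NC(N)=O)s2)cc1`, 2200 nM
Compound 2: `NC(=O)Nc1sc(-c2ccccc2)cc1C(=O)NCC1CNCCO1`, "not determined" (no result reported)
Compound 3: `NC(=O)Nc1sc(-c2ccccc2)cc1C(=O)NC1CCOCC1`, "not determined" (no result reported)

Three compounds that share the same core were examined in a functional assay on HT-29 cells (Homo sapiens); on this read-out higher numbers stand for an effect only at larger amounts of compound and lower numbers for an effect already at smaller amounts. Within the data shown here, compound 1 is the only one with a number: in this assay compound 1 gives 2200 nM. Among the measured compounds shown here, for compound 2 the outcome in this assay is "not determined" (no result reported), and for compound 3 it is likewise "not determined" (no result reported), so no comparison between measured compounds can be drawn, and compound 1 stands alone as the sole reference point.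

The step of interest leads to compound 4, `CNC(=O)c1ccc(-c2cc(C(=O)N[C@H]3CCCNC3)c(NC(N)=O)s2)cc1`, which has not yet been tested. Compared with compound 1 it differs in one place: methylcarbamoyl in place of methanesulfonamido on an aromatic carbon. The exchange sits on an aromatic carbon of a six-membered aromatic ring of carbon only.

For the measured compounds named here, with no measured pair to calibrate the effect of this exchange, the expectation rests on compound 1 alone. The step from compound 1 to compound 4 is expected to be small, a 1.1-fold higher number from compound 1 to compound 4 (0.06 log units; within the scatter), not clearly beyond the scatter in either direction. Compound 4 is therefore estimated to give 2500 nM in this assay, with a range from 900 nM to 7000 nM.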

Compound 4, half-maximal effective concentration: 4300 nM
Compound 4: middle estimate off by 1.7-fold (0.24 log units), on the low side; the range from low to high includes it.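

With compound 4, the aromatic carbon para to a large group has its first measured exchange, and in this assay replacing methanesulfonamido with methylcarbamoyl gives a 2.0-fold higher number from compound 1 to compound 4 (0.29 log units; within the scatter), a step that does not separate the two compounds. The sulfonamide, with its sulfur, is therefore not required at this position for a reading of similar size in this assay, since the carbon-linked methylcarbamoyl, with one heavy atom fewer, stays within the usual spread of compound 1. No measured property or other independent information is available to explain why the two groups read alike.

This single pair says nothing about how far the position can be changed before the reading moves beyond the scatter, and a primary amine, a carboxylic acid or a longer chain on the amide nitrogen at the same aromatic carbon could behave quite differently. From the compounds shown here alone, it is also open whether the similarity of the two groups would hold with another side chain on the carboxamide of the shared core, or in any read-out other than this assay.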